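A few compounds are considered here, and "the series" means these few. Any claim that something is new, unique, unknown or untested is made for them only; others in the source may bear on it.

Working notes on a small urea series. Compound 1 `Cc1ccc(S(=O)(=O)NC(=O)Nc2cc(C(C)(C)C)nn2-c2ccccc2)cc1` carries a tolylsulfonyl urea; in an assay on isolated protein for inhibition of Ephrin type-A receptor 2 (Homo sapiens), read by thermal shift assay, tested at 10 uM (on this read-out higher numbers stand for stronger stabilisation of the target against heat and lower numbers for weaker stabilisation of the target), compound 1 gives 0.2 degrees C. Compound 2 `Cc1ccc(-n2nc(C(C)(C)C)cc2NC(=O)Nc2cc(C(F)(F)F)cc(C(F)(F)F)c2)cc1` instead carries a bis(trifluoromethyl)phenyl urea on the same pyrazole core; in this assay compound 2 gives 0.8 degrees C. Compound 2 is the upper of the two numbers recorded, but compound 1 sits within the scatter of it, so the two are not separated.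

Compound 3 `CC(C)(C)c1cc(NC(=O)Nc2cc(C(F)(F)F)cc(C(F)(F)F)c2)n(-c2ccc(Br)cc2)n1` is compound 2 with one change: bromo in place of methyl on an aromatic carbon, read one bond further out as 4-methylphenyl to 4-bromophenyl. Within the data shown here, no measured pair shows this change, so nothing sets its size. Given that both measured values sit near zero in this assay, the expected step is no change at the digits printed from compound 2 to compound 3 (within the scatter), none beyond the scatter. For compound 3 the estimate in this assay is 0.8 degrees C, within -0.3 degrees C to 1.9 degrees C.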

Compound 3, shift of the target's melting temperature: 0.3 degrees C
For compound 3 the middle estimate is 0.50 degrees C above the measured one; low and high end bracket the measured number.
By their numbers in this assay, from the lowest: compounds 1, 3 and 2 (each within the scatter of the next).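

Bromo in place of methyl on an aromatic carbon, para to a large group, gives a number 0.50 degrees C lower from compound 2 to compound 3 (within the scatter) in this assay. Among these compounds, this is the first step read at this position, and it does not separate 4-methylphenyl from 4-bromophenyl, so the two compounds stand as equal within this read-out. Nothing at hand bears on the origin of the printed difference.

Open, going by these compounds, is whether a group of another kind at this position, such as an amine, a carboxylic acid or a longer alkyl chain, would give a step beyond the scatter from compound 2. Also open, on these data alone, is whether any single change elsewhere on compound 2, including in the bis(trifluoromethyl)phenyl part of the urea, would raise the shift of the melting temperature clearly above the values seen so far.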